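The source may hold more compounds than are shown below. What is called first, only, known or untested is meant among the compounds shown, and "the series" means these compounds.

Measured in a functional assay with Homo sapiens as the target; a lower number here means a stronger inhibitor, a higher number a weaker inhibitor:
- Compound 1 `CC(C)[C@H](NC(=O)COc1cccc2ccccc12)C(=O)N[C@@H](CC(=O)O)C(=O)COc1ccc2ccccc2c1` gives 15900 nM
- Compound 2 `CC(C)[C@H](NC(=O)COc1cccc2ccccc12)C(=O)N[C@@H](CC(=O)O)C(=O)COc1ccc(C#N)cc1` gives 26700 nM
- Compound 3 `CC(C)[C@H](NC(=O)COc1cccc2ccccc12)C(=O)N[C@@H](CC(=O)O)C(=O)COc1ccc(F)cc1` gives 14300 nM

The three compounds share a core and differ only in the group on an oxygen on a saturated carbon. Compound 3, at 14300 nM in this assay, cannot be told apart from the other two. Both a 1.1-fold lower number from compound 1 to compound 3 (0.05 log units; within the scatter) and a 1.9-fold lower number from compound 2 to compound 3 (0.27 log units; within the scatter) lie within the scatter, as does a 1.7-fold higher number from compound 1 to compound 2 (0.23 log units; within the scatter) in the same series.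

Compound 4 `CC(C)[C@H](NC(=O)COc1cccc2ccccc12)C(=O)N[C@@H](CC(=O)O)C(=O)COc1ccc(F)c(F)c1F` keeps the core of compound 3 and carries 2,3,4-trifluorophenyl in place of 4-fluorophenyl on that oxygen: 2,3,4-trifluorophenyl in place of 4-fluorophenyl on an oxygen on a saturated carbon. For the measured compounds named here, no measured compound carries 2,3,4-trifluorophenyl, so no step measures this change directly. The closest evidence is the exchange of fluoro for cyano on an aromatic carbon, a 1.9-fold lower number from compound 2 to compound 3 (0.27 log units; within the scatter), and the exchange of naphthalen-2-yl for 4-fluorophenyl, a 1.1-fold lower number from compound 1 to compound 3 (0.05 log units; within the scatter). Since these exchanges stayed within the scatter, no step beyond the scatter is expected in this assay, although three compounds cannot rule one out. The estimate is for a small move at most, with an expected 1.4-fold lower number from compound 3 to compound 4 (0.16 log units; within the scatter). For compound 4 the estimated value is 10000 nM, with an expected range from 3000 nM to 25000 nM.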

Compound 4, half-maximal inhibitory concentration: 20600 nM
For compound 4 the middle estimate is 2.1-fold (0.31 log units) below the measured one; the range from low to high includes it.
By their numbers in this assay, from the lowest: compounds 3, 1, 4 and 2 (each within the scatter of the next).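

Within this assay, the 2,3,4-trifluorophenyl group is the first to change the fluorine substitution on an aromatic ring at this position, and that change from 4-fluorophenyl stays within the scatter (a 1.4-fold higher number from compound 3 to compound 4 (0.16 log units; within the scatter)). The new group is also within the scatter of the other two groups on this oxygen on a saturated carbon, as shown by the exchange for 4-cyanophenyl (a 1.3-fold lower number from compound 2 to compound 4 (0.11 log units; within the scatter)) and the exchange for naphthalen-2-yl (a 1.3-fold higher number from compound 1 to compound 4 (0.11 log units; within the scatter)), so all four compounds remain indistinguishable in this read-out and the added fluorine opens no separation among them. Nothing in the available evidence bears on why this position responds so little.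

The compounds shown leave open whether any group on this oxygen can move the number beyond the scatter, for instance an amine or a carboxylic acid on the aromatic ring, or a longer saturated chain in place of the ring. They also leave open whether the shared core, which stays the same throughout, has more influence on the number than this position does.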